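The source may report more compounds than this note shows. Statements on the series, on what has been measured and on what is new or still open speak of the compounds shown alone.

Of the compounds shown here, three that share a core have been measured in a functional assay on M14 cells (Homo sapiens) for inhibition, read by sulforhodamine B assay, with a stated time of 48 h; a higher number here means a weaker inhibitor of growth, a lower number a stronger inhibitor of growth. Compound 1 `N=C(N)c1ccc(-c2ccc(-c3ccc(Cl)cc3)s2)s1` gives 1710 nM. Compound 2 `COc1cc(OC)cc(-c2ccc(-c3ccc(C(=N)N)o3)o2)c1` gives 2070 nM in this assay, and compound 3 `N=C(N)c1ccc(-c2ccc(-c3ccccc3)o2)o1` gives 1620 nM. Among these three numbers compound 1 holds the second highest, yet its gap to compound 3, the nearest, and its gap to compound 2, the furthest, both fall within the scatter of repeated measurement, so no order among the three can be read from them; they behave as one group of roughly equal growth inhibitors.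

Compound 4 `N=C(N)c1ccc(-c2ccc(-c3ccc(F)cc3)s2)s1` has not yet been measured in this assay. It differs from compound 1 by fluoro in place of chloro on an aromatic carbon. For the measured compounds named here, no pair of measured compounds in this set differs in a single place, so there is no observed step of this kind to lean on, and the size of the change must be estimated from the spread of the three measured values alone.

Because compound 1 gives 1710 nM and the whole measured set lies within scatter of that number, the change is expected to amount to a 1.1-fold higher number from compound 1 to compound 4 (0.05 log units; within the scatter), that is, nothing beyond the scatter in either direction. Compound 4 is therefore estimated at 1900 nM, with a plausible range from 900 nM to 4000 nM.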

Compound 4, concentration for 50% growth inhibition: 1890 nM
Beside the measured number, compound 4's estimate is 1.0-fold (0.00 log units) above it, and the stated range covers the measured number.
By their numbers in this assay, from the lowest: compounds 3, 1, 4 and 2 (each within the scatter of the next).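

In this assay, for the compounds shown here, the exchange of chloro for fluoro on an aromatic carbon of a six-membered aromatic ring of carbon only, para to a large group, gives a 1.1-fold higher number from compound 1 to compound 4 (0.04 log units; within the scatter) and is the first step in the set that changes a single place. Going by these compounds alone, it shows that, on the core of compound 1, these two halogens cannot be told apart at this position by growth inhibition in this assay, whereas the earlier compounds, which differ in more than one place, could say nothing about this position on its own. Compound 4 thus joins the three earlier compounds as one group of roughly equal growth inhibitors, and nothing at hand bears on why the exchange leaves the number within the scatter.

The compounds shown leave open whether any group other than these two halogens in this place, such as methoxy, trifluoromethyl, an amine or a carboxylic acid, would move the number beyond the scatter. They also leave open whether plain hydrogen in this place on the core of compound 1 would read any differently, and so whether a halogen here matters at all.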